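Trimming the Side Chain on a Weaker Sulfonamide

A few compounds are considered here, and "the series" means these few. Any claim that something is new, unique, unknown or untested is made for them only; others in the source may bear on it.

Compound 1 `CCC(C)C(C(=O)Nc1ccc(C(C)=O)cc1)N(C(=O)c1ccccc1)S(=O)(=O)c1ccc(C)cc1` carries a sec-butyl group and a (4-methylphenyl)sulfonyl group. In a functional assay for inhibition, read by spectrophotometry, with a stated time of 20 min, tested at 3 mg/mL (a lower number here means a weaker effect, a higher number a stronger effect of the compound at the concentration tested), compound 1 gives 33.4%. Compound 2 `CC(=O)c1ccc(NC(=O)C(C(C)C)N(C(=O)c2ccccc2)S(=O)(=O)c2ccc(C)cc2)cc1` differs from it by hydrogen in place of methyl on a saturated chain carbon, three bonds along the chain from an amide-type nitrogen and a carbonyl carbon; in this assay compound 2 gives 29.7%, and the step of a number 3.7 percentage points lower from compound 1 to compound 2 (within the scatter) is one the scatter swallows. Compound 3 `CCC(C)C(C(=O)Nc1ccc(C(C)=O)cc1)N(C(=O)c1ccccc1)S(=O)(=O)c1ccccc1` differs from compound 1 by hydrogen in place of methyl on an aromatic carbon; in this assay compound 3 gives 14.3%, and the step of a number 19.1 percentage points lower from compound 1 to compound 3 (beyond the scatter) lies beyond the scatter, so compound 3 stands lowest of the three measured compounds.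

Compound 4 `CC(=O)c1ccc(NC(=O)C(C(C)C)N(C(=O)c2ccccc2)S(=O)(=O)c2ccccc2)cc1` is not yet measured. It differs from compound 3 by hydrogen in place of methyl on a saturated chain carbon, three bonds along the chain from an amide-type nitrogen and a carbonyl carbon, the same change that turned compound 1 into compound 2, now made on the core of compound 3 rather than the core of compound 1. From compound 3 to compound 4 a step of similar size is expected, a number 3.3 percentage points lower from compound 3 to compound 4 (within the scatter), because the earlier step of a number 3.7 percentage points lower from compound 1 to compound 2 (within the scatter) stayed within the scatter, though a single earlier example is all that supports this. Compound 4 is therefore expected to give about 11% in this assay, between 2% and 22%.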

Compound 4, a percentage reported as inhibition, at one concentration (the size of the read-out at that concentration, not a potency): 47.5%
Estimate against measurement, compound 4: 36.5 percentage points below; measured number outside the range, above it.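

In this assay, the change from sec-butyl to isopropyl gives a number 33.2 percentage points higher from compound 3 to compound 4 (beyond the scatter), so it does not behave as it did on the core of compound 1: the same change on two cores in this assay, a number 3.7 percentage points lower (within the scatter) from compound 1 to compound 2 and a number 33.2 percentage points higher (beyond the scatter) from compound 3 to compound 4, 36.9 percentage points apart, beyond the scatter of two such steps

The change from methyl to hydrogen on the aromatic carbon also behaves differently on the two cores, here giving a number 17.8 percentage points higher from compound 2 to compound 4 (beyond the scatter): the same change on two cores in this assay, a number 19.1 percentage points lower (beyond the scatter) from compound 1 to compound 3 and a number 17.8 percentage points higher (beyond the scatter) from compound 2 to compound 4, 36.9 percentage points apart, beyond the scatter of two such steps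

In these compounds, then, the effect of one change depends on the other, and a step measured on one core cannot simply be carried to the other; but this is a single set of four compounds read at one concentration, which shows neither why the steps differ nor how far the pattern extends.

On these data alone, it remains open whether a longer chain in place of sec-butyl or isopropyl would follow either core's behaviour. The same question applies to a chlorine atom or a methoxy group in place of the methyl on the aromatic carbon.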